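The source may hold more compounds than are shown below. What is called first, only, known or untested is meant among the compounds shown, and "the series" means these compounds.

Measured so far in a functional assay on HeLa cells (Homo sapiens) for antiproliferative activity, read by CCK-8 assay, with a stated time of 72 h, tested at 8 uM; a higher number here means a stronger effect of the compound at the concentration tested, a lower number a weaker effect:

compound 1, `Nc1ccccc1NC(=O)c1ccc(CSC(=S)N2CCCc3ccccc32)cc1`, gives 35.7%
compound 2, `Nc1ccccc1NC(=O)c1ccc(CSC(=S)N2CCN(Cc3ccncc3)CC2)cc1`, gives 72.9%

Compound 2 stands at the top of the two numbers; compound 1 is the nearest point and sits far lower, a gap beyond the usual scatter of this assay. Among the compounds with values here, the two compounds differ in more than one place, so no single structural step connects them, and the two values are taken only as they stand.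

Compound 3, `Nc1ccccc1NC(=O)c1ccc(CSC(=S)N2CCN(Cc3ccccc3)CC2)cc1`, has not yet been measured in this assay . It is derived from compound 2 by one change: phenyl in place of pyridin-4-yl on a saturated chain carbon bound to an amine nitrogen in a ring. Within the data shown here, nothing among the measured pairs reports this exact change, so no measured step sets its size. The expectation for compound 3 is therefore anchored on the value of compound 2, with a step of a number 8.9 percentage points lower from compound 2 to compound 3 (within the scatter), expected to fall within the scatter or to be a modest decrease at most. The estimate for compound 3 in this assay is 64%, with a range from 42% to 82%.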

Compound 3, a percentage reported as inhibition, at one concentration (the size of the read-out at that concentration, not a potency): 31.3%
For compound 3 the middle estimate is 32.7 percentage points above the measured one, outside the stated range (below it).
By their numbers in this assay, from the lowest: compounds 3 and 1 (each within the scatter of the next); then compound 2.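

Within the data shown here, this is the first step that changes one place only: in this assay, phenyl in place of pyridin-4-yl on a saturated chain carbon bound to an amine nitrogen in a ring comes with a number 41.6 percentage points lower from compound 2 to compound 3 (beyond the scatter). The two groups match in heavy-atom count and neither carries a net charge, so the exchange amounts to a ring carbon in place of the ring nitrogen, with the loss of the one hydrogen-bond acceptor counted in the leaving group, and the read-out at this single concentration is clearly sensitive to that difference. No measured data bear on what lies behind the step, so it stands as an observation only.

The compounds shown leave open whether the ring nitrogen has to stand where it does in pyridin-4-yl, which pyridin-3-yl or pyridin-2-yl on the same carbon would test. Also open, from the compounds shown here alone, is whether an aromatic ring is needed on that carbon at all, a question that a methyl or a 2-hydroxyethyl group in its place would address.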